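The compounds below may be only part of what the source reports. "The series", "measured", "known", "first", "only" and "open" are said of these compounds alone.

Compound 1, `CCN(CC)S(=O)(=O)c1ccc(S(=O)(=O)N2CCC[C@@H](C(=O)N3CCOCC3)C2)cc1`, gives in a functional assay on MIA PaCa-2 cells (Homo sapiens) for inhibition, read by MTT assay, with a stated time of 3 days (on this read-out higher numbers stand for weaker inhibition and lower numbers for stronger inhibition), only a limit, > 10000 nM.
Compound 2, `CN(C)S(=O)(=O)c1ccc(S(=O)(=O)N2CCC[C@@H](C(=O)N3CCC(F)(F)CC3)C2)cc1`, gives in this assay only a limit, > 3000 nM.

Compound 1 stands at a limit (the limit of > 10000 nM in this assay, at which 1 of the 2 values shown sits), so no number is known for it, only that its inhibition is too weak to be measured. Compound 2 stands at a limit as well (the limit of > 3000 nM in this assay, at which 1 of the 2 values shown sits). For the measured compounds named here, no step between measured compounds exists here, so nothing measured tells how a change of structure moves potency in this assay.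

Compound 3, `CCN(CC)S(=O)(=O)c1ccc(S(=O)(=O)N2CCC[C@@H](C(=O)N[C@@H]3CCOC3)C2)cc1`, differs from compound 1 in one place ((oxolan-3-yl)amino in place of morpholin-4-yl on a carbonyl carbon). The same atoms are joined differently: the morpholin-4-yl group, one six-membered non-aromatic ring with 2 hetero atoms, leaves, and the (oxolan-3-yl)amino group, one five-membered non-aromatic ring with 1 hetero atom and 1 hydrogen-bond donor, enters on the carbonyl carbon. Going by the values given here, the two measured compounds give no step to judge such a change by.

The step of a number no higher from compound 1 to compound 3 (the limit leaves the size open) is expected to be none beyond the scatter, leaving compound 3 near the limit. Compound 3 is estimated at 10000 nM, in a range from 3000 nM to 30000 nM.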

Compound 3, half-maximal inhibitory concentration: > 10000 nM
Compound 3 ended at the assay's limit (the forecaster's own chance of this, stated with the estimate: 70%); the middle value sits exactly at the limit.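

In this assay, for the compounds shown here, compound 3 gives only a limit, as compound 1 does, and no step between these two compounds can be read. The compounds shown leave open whether the one structural difference between these two compounds changes potency at all, and how strong the inhibition of either compound actually is.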